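This account rests on a few compounds, and the source may have more. Where it says the series, first, only, none or still open, it means among the compounds named here.

Measured so far in an in vitro ADME assay on microsomes (Rattus norvegicus) for metabolic stability; on this read-out higher numbers stand for a longer-lived compound and lower numbers for a shorter-lived compound
compound 1 `CCc1nc(-c2ccc(OC(F)(F)F)cc2OC)c(CC)nc1NC(CC)CC` gives 0.0417 h
compound 2 `CCc1nc(-c2ccc(Cl)cc2Cl)c(CC)nc1NC(C1CC1)C1CC1` gives 0.0417 h
compound 3 `CCc1nc(-c2ccc(OC(F)(F)F)cc2OC)c(OC)nc1NC(CC)CC` gives 0.6 h

Compound 1 stands level with compound 2 at the digits shown, and together they hold the lowest number of the three. Compound 4 `CCc1nc(-c2ccc(C)cc2OC)c(CC)nc1NC(CC)CC` carries methyl in place of trifluoromethoxy on an aromatic carbon, meta to a methoxy group and para to a large group (methyl in place of trifluoromethoxy on an aromatic carbon). Within the data shown here, the only measured step is methoxy in place of ethyl on an aromatic carbon, and it is large (a 14-fold higher number from compound 1 to compound 3 (1.16 log units; beyond the scatter)). That step lies elsewhere on the molecule and compound 4 keeps the ethyl in question, so it sets no size for this change. Among the measured compounds shown here, no measured step covers the exchange of trifluoromethoxy for methyl. Compound 2, which differs in several places and has no trifluoromethoxy group, gives 0.0417 h in this assay, the same number as compound 1. No step beyond the scatter is therefore expected (a 1.2-fold higher number from compound 1 to compound 4 (0.08 log units; within the scatter)). For compound 4 the estimate is 0.05 h with 0.025 h to 0.15 h as the expected range.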

Compound 4, half-life: < 0.0167 h
Compound 4: only a limit was reported (the forecaster's own chance of this, stated with the estimate: 10%); middle value at least 2.9-fold (0.47 log units) away from the limit.
By their numbers in this assay, from the lowest: compounds 1 and 2 (each within the scatter of the next); then compound 3. At a limit, below all of these: compound 4.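

The position para to a large group on the aromatic ring now has a measured change in this assay: methyl in place of trifluoromethoxy gives an at least 2.4-fold lower number from compound 1 to compound 4 (0.39 log units; beyond the scatter). Among these compounds, the earlier compounds showed a step only at the ethyl that methoxy replaces, so this is the first sign that the series also responds to a change at this second site, and here the change moves towards a shorter-lived compound. Compound 4 is reported only as a limit of the assay, and the step therefore gives a minimum size and no exact one: the limit of < 0.0167 h in this assay, at which 1 of the 4 values shown sits.

The compounds shown leave open how a nitrile or a carboxylic acid at this position would compare with trifluoromethoxy and methyl. They also leave open whether the same exchange would give a step of similar size on compound 3, which gives 0.6 h.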